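A few compounds are considered here, and "the series" means these few. Any claim that something is new, unique, unknown or untested is made for them only; others in the source may bear on it.

Series notes. Compound 1 `Cc1cc(C)c(-c2nc3ccccc3[nH]2)cc1NC(=O)c1ccc(OCc2ccccn2)cc1` gives 30 mL.min-1.g-1 in an ADME assay on microsomes from liver (Homo sapiens) for metabolic stability; on this read-out higher numbers stand for fast clearance and lower numbers for slow clearance. For the measured compounds named here, compound 2 `Cc1cc(C)c(-c2ccc(N)cn2)cc1NC(=O)c1ccc(OCc2ccccn2)cc1` gives 9 mL.min-1.g-1 in this assay; it holds the lowest of the two numbers so far, with compound 1 the nearest, and the step of a 3.3-fold lower number from compound 1 to compound 2 (0.52 log units; beyond the scatter) lies beyond the scatter. Compound 3 `Cc1cc(C)c(-c2cccc(N)n2)cc1NC(=O)c1ccc(OCc2ccccn2)cc1` is not yet measured in this assay. Its difference from compound 2: 6-aminopyridin-2-yl in place of 5-aminopyridin-2-yl on an aromatic carbon. Either aminopyridinyl group sits on the same carbon of the shared core, ortho to a methyl group, meta to a large group and para to a methyl group. Going by the values given here, the only measured step, a 3.3-fold lower number from compound 1 to compound 2 (0.52 log units; beyond the scatter), exchanges one whole heteroaryl group for another and therefore bears only loosely on a shift of the amino group within the pyridin-2-yl ring; no measured step in this set moves a substituent around that ring. On that basis no step beyond the scatter is expected in this assay, and compound 3 is expected to land near compound 2. Estimate for compound 3 in this assay: 10 mL.min-1.g-1, with a range of 4 mL.min-1.g-1 to 25 mL.min-1.g-1. The expected step is a 1.1-fold higher number from compound 2 to compound 3 (0.05 log units; within the scatter).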

Compound 3, intrinsic clearance in microsomes in the Homo sapiens assay: 88 mL.min-1.g-1
Estimate against measurement, compound 3: 8.8-fold (0.94 log units) below; the whole stated range lies below it.
By their numbers in the Homo sapiens assay, from the lowest: compound 2; then compound 1; then compound 3.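

In the Homo sapiens assay compound 2 gives 9 mL.min-1.g-1 and compound 3 gives 88 mL.min-1.g-1. In the Homo sapiens assay, with the same atoms joined differently, the shift of the amino group on the pyridin-2-yl ring at this position on the shared core gives a 9.8-fold higher number from compound 2 to compound 3 (0.99 log units; beyond the scatter). The identity of the ring alone therefore does not set the number, since the two aminopyridinyl groups, with the same counts of heavy atoms, donors and acceptors, differ widely in this read-out. The 1H-benzimidazol-2-yl group of compound 1 now falls between them, as a 3.3-fold lower number from compound 1 to compound 2 (0.52 log units; beyond the scatter) points one way and a 2.9-fold higher number from compound 1 to compound 3 (0.47 log units; beyond the scatter) points the other.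

In a physicochemical assay for lipophilicity (on this read-out higher numbers stand for higher lipophilicity and lower numbers for lower lipophilicity), compound 2 gives 3.2. In the physicochemical assay compound 3 gives > 3, which is a limit and not a number. The step from compound 2 to compound 3 in that assay therefore cannot be read: the limit of > 3 in the physicochemical assay, at which 1 of the 2 values shown sits. As far as these compounds go, whether the two aminopyridinyl compounds differ in lipophilicity at all stays open, as does whether a methoxy or a dimethylamino group in place of the amino group of compound 3 would keep the higher clearance number or bring it back towards that of compound 2.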